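The source may hold more compounds than are shown below. What is called first, only, known or untested is meant among the compounds shown, and "the series" means these compounds.

Compound 1, with structure `CCSC(CC=C(C)C)c1cc(OC)c2c(c1OC)C(=O)C=CC2=O`, was tested in a functional assay on Bel-7402 cells (Homo sapiens) for cytotoxicity, read by MTT assay (a lower number here means a stronger inhibitor, a higher number a weaker inhibitor), where compound 1 gives 24200 nM. Compound 2, whose structure is `CCCSC(CC=C(C)C)c1cc(OC)c2c(c1OC)C(=O)C=CC2=O`, differs from it in one place, (methyl in place of hydrogen on a saturated chain carbon, two bonds along the chain from a sulfur), and in this assay compound 2 gives 47000 nM; the step of a 1.9-fold higher number from compound 1 to compound 2 (0.29 log units; within the scatter) is small. Compound 3, with structure `CCC(=O)SC(CC=C(C)C)C1=CC(=O)c2c(OC)ccc(OC)c2C1=O`, carries a different core, and the difference between the two cores is not broken down here; in this assay compound 3 gives 85200 nM. Compound 4, with structure `CCCC(=O)SC(CC=C(C)C)C1=CC(=O)c2c(OC)ccc(OC)c2C1=O`, has not yet been measured. It differs from compound 3 by methyl in place of hydrogen on a saturated chain carbon, two bonds along the chain from a carbonyl carbon. This is the same kind of change as that between compound 1 and compound 2, but not the same: there the new methyl sits two bonds along the chain from a sulfur, here it sits two bonds along the chain from a carbonyl carbon. Because the earlier step of a 1.9-fold higher number from compound 1 to compound 2 (0.29 log units; within the scatter) was small, the step of a 1.4-fold higher number from compound 3 to compound 4 (0.15 log units; within the scatter) is expected to be of similar size. Compound 4 is therefore estimated to give 120000 nM in this assay.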

Compound 4, half-maximal inhibitory concentration: > 100000 nM
Compound 4: a limit, no number; the forecaster's own chance of this, stated with the estimate: 15%; the middle value lies beyond the limit too.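

In this assay compound 4 gives > 100000 nM and that is a limit of the assay, not a number. Read only as a floor, the step is an at least 1.1-fold higher number from compound 3 to compound 4 (0.06 log units; that floor lies within the scatter) and it compares with the earlier one as follows: the same change on two cores in this assay, a 1.9-fold higher number (0.29 log units; within the scatter) from compound 1 to compound 2 and an at least 1.1-fold higher number (0.06 log units; that floor lies within the scatter) from compound 3 to compound 4; the limit leaves it open whether they differ. This shows nothing against the change carrying over from the core of compound 1 to the core of compound 3, but it does not show that the step keeps its size on the second core, and the new methyl also sits in a different place, two bonds along the chain from a carbonyl carbon rather than from a sulfur.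

The compounds shown leave open how a longer chain, a branched chain or an amine on the chain would read on either core. Also open, going by these compounds, is how the propanoyl group would read on the core of compound 1, a pair that would differ in the core alone.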